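The source may report more compounds than this note shows. Statements on the series, on what has been measured and on what is new or still open speak of the compounds shown alone.

Three compounds here share one core and were tested in a functional assay on A-431 cells (Homo sapiens) for cytotoxicity, read by MTT assay, with a stated time of 24 h; on this read-out lower numbers stand for stronger inhibition and higher numbers for weaker inhibition. Compound 2 `COc1ccc(/C=C\C(=O)O)c(OCc2cn(-c3cccc(C#N)c3)nn2)c1CC=C(C)C` gives 22900 nM in this assay. Compound 1 `COc1ccccc1-n1cc(COc2c(/C=C\C(=O)O)ccc(OC)c2CC=C(C)C)nn1` gives 32600 nM in this assay, and compound 3 `COc1ccc(/C=C\C(=O)O)c(OCc2cn(-c3ccccc3C(=O)N3CCC(O)C3)nn2)c1CC=C(C)C` gives 31500 nM in this assay. Compound 2 has the lowest of the three numbers, but both of its neighbours lie within the scatter of it, so nothing separates the three. The two measured steps, a 1.4-fold lower number from compound 1 to compound 2 (0.15 log units; within the scatter) and a 1.0-fold lower number from compound 1 to compound 3 (0.01 log units; within the scatter), both stay within the scatter.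

Compound 4 `COc1ccc(/C=C\C(=O)O)c(OCc2cn(-c3ccc(C#N)cc3)nn2)c1CC=C(C)C` is the untested member. The change is 4-cyanophenyl in place of 3-cyanophenyl on an aromatic nitrogen. Going by the values given here, the only measured step at the same aromatic nitrogen is the one from compound 1 to compound 2, and it stayed within the scatter; no measured step moves a nitrile around the ring. With so little to go on, the expected step is a 1.0-fold higher number from compound 2 to compound 4 (0.02 log units; within the scatter), no movement beyond the scatter. For compound 4 the estimate in this assay is 24000 nM, with a range from 9000 nM to 60000 nM.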

Compound 4, half-maximal inhibitory concentration: 23000 nM
Estimate against measurement, compound 4: 1.0-fold (0.02 log units) above; the measured number falls inside the stated range.
By their numbers in this assay, from the lowest: compounds 2, 4, 3 and 1 (each within the scatter of the next).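

In this assay, the change to 4-cyanophenyl in place of 3-cyanophenyl gives a 1.0-fold higher number from compound 2 to compound 4 (0.00 log units; within the scatter) and so offers the first measured move of a nitrile around this ring on the aromatic nitrogen. The step stays within the scatter, so these two nitrile placements are not told apart here. Against the 2-methoxyphenyl group, the 4-cyanophenyl group gives a 1.4-fold lower number from compound 1 to compound 4 (0.15 log units; within the scatter) and also stays within the scatter, so neither cyanophenyl group is separated from compound 1.

The compounds shown leave open whether an amine or a carboxylic acid on this phenyl ring in place of the nitrile, or a longer chain there, would produce a step beyond the scatter. No other measurement shown accounts for the numbers at this position.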